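Replacing a pyrazole by a succinyl hydrazide on a phenoxyacetyl arm

The compounds below may be only part of what the source reports. "The series", "measured", "known", "first", "only" and "open" are said of these compounds alone.

In a functional assay on the whole organism (strain Wistar) for inhibition, with Rattus norvegicus as the target, read by paw edema, with stated times of 30 min and 3 h, at a dose of 20 mg/kg (a lower number here means less inhibition, a higher number more inhibition at the dose given (going by the name of the read-out)), compound 2 `CCOC(=O)C1=C(C)NC(C)=C(C(=O)OCC)C1c1ccc(OCC(=O)n2nc(C)cc2C)cc1` gives 48.5%, and compound 1 `CCOC(=O)C1=C(C)NC(C)=C(C(=O)OCC)C1c1ccc(OCC(=O)NNC(=O)c2ccc(C)cc2)cc1` gives 47.3%, the two numbers lying within the scatter of each other. Compound 3 `CCOC(=O)C1=C(C)NC(C)=C(C(=O)OCC)C1c1ccc(OCC(=O)NNC(=O)CCC(=O)O)cc1` has not been measured; it differs from compound 2 by a group of 9 heavy atoms (4 carbon, 2 nitrogen, 3 oxygen; no ring) in place of a group of 7 heavy atoms (5 carbon, 2 nitrogen; one five-membered aromatic ring with 2 hetero atoms), on a carbonyl carbon. Among the compounds with values here, the only step available is a number 1.2 percentage points higher from compound 1 to compound 2 (within the scatter), which changed the same position without moving the read-out beyond the scatter. The change to compound 3 is therefore expected to give no step beyond the scatter, an estimated a number 1.5 percentage points lower from compound 2 to compound 3 (within the scatter). Compound 3 is estimated at 47%, between 35% and 58%.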

Compound 3, a percentage reported as inhibition, in the whole organism at one dose (the size of the read-out at that dose, not a potency): 56.9%
Beside the measured number, compound 3's estimate is 9.9 percentage points below it; the measured number falls inside the stated range.
By their numbers in this assay, from the lowest: compounds 1, 2 and 3 (each within the scatter of the next).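

In this assay, the carbonyl carbon carries an open chain with no ring as readily as a ring-bearing group: replacing 3,5-dimethyl-1H-pyrazol-1-yl gives a number 8.4 percentage points higher from compound 2 to compound 3 (within the scatter), and 2-carboxyethyl in place of 4-methylphenyl gives a number 9.6 percentage points higher from compound 1 to compound 3 (within the scatter). Neither the five-membered aromatic ring nor the 4-methylphenyl group is therefore needed to keep the read-out at this dose. No measurement available here bears on the reason for these steps.

Still open, on these data alone, is how a longer chain such as 3-carboxypropyl, or an amine such as 2-aminoethyl, would read in place of 2-carboxyethyl. As far as these compounds go, whether any group at this position can move the read-out beyond the scatter also remains open.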